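A few compounds are considered here, and "the series" means these few. Any claim that something is new, unique, unknown or untested is made for them only; others in the source may bear on it.

Compound 1, `CS(=O)(=O)N1CC(CCl)c2ccc(O)cc21`, gives 1900 nM in a functional assay on UV4 cells (Cricetulus griseus) for cytotoxicity, with a stated time of 4 h; on this read-out higher numbers stand for weaker inhibition and lower numbers for stronger inhibition.
Compound 2, `CS(=O)(=O)N1CC(CCl)c2ccc(N)cc21`, gives 13000 nM in this assay.
Compound 3, `CSc1ccc2c(c1)N(S(C)(=O)=O)CC2CCl`, gives only a limit of the assay in this assay, > 200000 nM.

From the compounds shown here alone, compound 3 is the weakest of the three in this assay: it sits at the limit of > 200000 nM in this assay, at which 1 of the 3 values shown sits, so its true number is unknown beyond that point. The step from compound 1 gave an at least 100-fold higher number from compound 1 to compound 3 (2.02 log units; beyond the scatter), and from compound 2 an at least 15-fold higher number from compound 2 to compound 3 (1.18 log units; beyond the scatter); both point the same way, toward much weaker inhibition with a methylsulfanyl group on the aromatic carbon.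

Compound 4, `CSSc1ccc2c(c1)N(S(C)(=O)=O)CC2CCl`, differs from compound 3 by methylsulfanyl in place of methyl on a sulfur. Among the compounds with values here, no measured pair shows a sulfur group growing in this way, so there is no step to read it against. Within the data shown here, the measured steps show only that compound 3 is already past the limit, and nothing in them suggests that lengthening the sulfur chain brings the number back down. The expectation for compound 4 in this assay is therefore no step beyond the scatter, a step that the limit leaves unreadable from compound 3 to compound 4, most likely with a limit reported again. Compound 4 is estimated at 300000 nM, between 50000 nM and 2000000 nM.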

Compound 4, half-maximal inhibitory concentration: > 50000 nM
Compound 4 ended at the assay's limit (the forecaster's own chance of this, stated with the estimate: 70%); the middle value is on the limit's open side.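

In this assay, putting (methylsulfanyl)sulfanyl on the aromatic carbon also moves the number well up from both the hydroxy and the amino compounds, giving an at least 26-fold higher number from compound 1 to compound 4 (1.42 log units; beyond the scatter) and an at least 3.8-fold higher number from compound 2 to compound 4 (0.58 log units; beyond the scatter). Methylsulfanyl is therefore no longer the only sulfur-bearing group shown to give much weaker inhibition at this position than hydroxy. Compound 3 and compound 4 are each reported only as a limit of the assay, so the step between them cannot be read, and growing methylsulfanyl into (methylsulfanyl)sulfanyl shows neither a gain nor a loss: the limit of > 50000 nM in this assay, at which 1 of the 4 values shown sits.

From the compounds shown here alone, how far past its limit compound 4 truly lies remains open. Also open, going by these compounds, is how a methoxy group, a carboxylic acid or a longer sulfur chain on this aromatic carbon would compare with hydroxy.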